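Chloro for hydrogen in a diaryl ether series: cytotoxicity notes

The compounds below may be only part of what the source reports. "The series", "measured", "known", "first", "only" and "open" are said of these compounds alone.

Three measured compounds share one core: compound 1 `CCCc1c(Cl)c(OC)c(Cl)c(O)c1Oc1c(Cl)c(O)c(Cl)c2c1C(=O)O[C@@H]2CC`, compound 2 `CCCc1cc(O)c(Cl)c(O)c1Oc1c(Cl)c(O)c(Cl)c2c1C(=O)O[C@@H]2CC` and compound 3 `CCCc1c(Cl)c(OC)cc(O)c1Oc1c(Cl)c(O)c(Cl)c2c1C(=O)O[C@@H]2CC`. In an ADME assay on MDCK cells (Canis lupus familiaris) for cytotoxicity, read by CellTiter-Glo, with a stated time of 40 h (on this read-out lower numbers stand for higher toxicity in this test and higher numbers for lower toxicity in this test), compound 1 reaches only the limit > 50000 nM. In this assay compound 2 likewise reaches only a limit, > 100000 nM. In this assay compound 3 stops at the limit > 50000 nM. Compound 1 differs from compound 3 by chloro in place of hydrogen on an aromatic carbon, and the step that the two limits leave unreadable from compound 3 to compound 1 cannot be read because the limit of > 50000 nM in this assay, at which 2 of the 3 values shown sit, holds both of its ends.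

Compound 4 `CCCc1c(Cl)c(O)c(Cl)c(O)c1Oc1c(Cl)c(O)c(Cl)c2c1C(=O)O[C@@H]2CC` is not yet measured. It arises from compound 2 through (chloro in place of hydrogen on an aromatic carbon), the same kind of change as that from compound 3 to compound 1, but the surroundings differ: in compound 4 the entering chloro sits ortho to a propyl group and para to a hydroxy group, whereas in compound 1 it sits ortho to a methoxy group and para to a propyl group. The difference between the cores of compound 2 and compound 3 is not broken down here. Given that the only earlier instance of this change is unreadable, the step from compound 2 to compound 4 is expected to be a number no higher from compound 2 to compound 4 (the limit leaves the size open). Compound 4 is expected to give 100000 nM in this assay, most likely again as a limit.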

Compound 4, half-maximal cytotoxic concentration: > 50000 nM
Compound 4 ended at the assay's limit; the forecaster's own chance of this, stated with the estimate: 80%; the middle value lies beyond the limit too.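

In this assay compound 4 also stops at a limit, and neither the step linking compound 2 with compound 4 nor the step linking compound 1 with compound 4 can be read, because limits hold their ends: the limit of > 50000 nM in this assay, at which 3 of the 4 values shown sit.

From the compounds shown here alone, whether chloro in place of hydrogen, or hydrogen in place of methyl on an oxygen, changes the half-maximal cytotoxic concentration at all stays open.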